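The source may report more compounds than this note shows. Statements on the series, on what has been measured and on what is new or still open speak of the compounds shown alone.

Working notes on the aryl group carried by the shared core, followed in an ADME assay on S9 fraction from liver (Mus musculus, strain ICR/CD-1) for metabolic stability, read by LC-MS, using NADPH, with a stated time of 5 min, tested at 2 uM; on this read-out lower numbers stand for a shorter-lived compound and higher numbers for a longer-lived compound. For the measured compounds named here, compound 1 `COc1ccccc1-c1cccc(S(=O)(=O)N2CCC(N3CCC(C)CC3)CC2)c1` gives 0.25 h, and compound 2 `CC1CCN(C2CCN(S(=O)(=O)c3cccc(-c4ccc(Cl)cc4)c3)CC2)CC1` gives 2.45 h, the higher of the two numbers so far. Going by the values given here, the only measured step, a 9.8-fold higher number from compound 1 to compound 2 (0.99 log units; beyond the scatter), comes with 4-chlorophenyl in place of 2-methoxyphenyl on an aromatic carbon and lies beyond the scatter.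

Next is compound 3 `Cc1cc(C)cc(-c2cccc(S(=O)(=O)N3CCC(N4CCC(C)CC4)CC3)c2)c1`, with 3,5-dimethylphenyl in place of 4-chlorophenyl on an aromatic carbon, meta to a large group: 3,5-dimethylphenyl in place of 4-chlorophenyl on an aromatic carbon. Among the compounds with values here, the single step above is the only evidence on swaps of this aryl group, so a change beyond the scatter is plausible but not assured. Within the data shown here, no measured compound carries the 3,5-dimethylphenyl group. Compound 2 at 2.45 h stands at the top of the two numbers, so a fall is the more likely direction, probably smaller than the step already seen. The expected change is a 3.1-fold lower number from compound 2 to compound 3 (0.49 log units; beyond the scatter). For compound 3 the estimated half-life is 0.8 h, with an expected range of 0.25 h to 2.2 h.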

Compound 3, half-life: > 4 h
Compound 3: no number, only a limit; the forecaster's own chance of this, stated with the estimate: 5%; at least 5.0-fold (0.69 log units) between middle value and limit.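

In this assay compound 3 gives > 4 h, which is a limit of the assay and not a number. The 3,5-dimethylphenyl group shows a second aryl group that clearly outlasts the 2-methoxyphenyl group, with an at least 16-fold higher number from compound 1 to compound 3 (1.20 log units; beyond the scatter), so the long half-life at this position is no longer tied to the 4-chlorophenyl group alone, and compound 1 is the short-lived member of the three. Against the 4-chlorophenyl group, the change is an at least 1.6-fold higher number from compound 2 to compound 3 (0.21 log units; that floor lies within the scatter), so its floor cannot put these two aryl groups in order, and any reading at the long-lived end of this set is capped: the limit of > 4 h in this assay, at which 1 of the 3 values shown sits.

On these data alone, it remains open how far compound 3 truly lies from compound 2, and whether the short half-life of compound 1 goes with the methoxy group itself or with its place on the ring. Also open, as far as these compounds go, is whether a pyridyl group, or a phenyl ring carrying a nitrile or a carboxylic acid, would keep the half-life near that of compound 2 or fall back towards that of compound 1.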